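Pyridin-4-yl Replaces Thiophen-3-yl on the Shared Core

This account rests on a few compounds, and the source may have more. Where it says the series, first, only, none or still open, it means among the compounds named here.

Of the compounds shown here, three on one core have been tested in an assay on isolated protein for inhibition of DNA topoisomerase 1 (Homo sapiens), with a stated time of 30 min, tested at 100 uM; a lower number here means a weaker effect, a higher number a stronger effect of the compound at the concentration tested. Compound 1 `Oc1ccc(-c2cc(-c3cccnc3)nc(-c3ccccc3Cl)c2)cc1` gives 0.9%, compound 2 `Oc1ccc(-c2cc(-c3cccs3)nc(-c3ccccc3Cl)c2)cc1` gives 2.2%, and compound 3 `Oc1ccc(-c2cc(-c3ccsc3)nc(-c3ccccc3Cl)c2)cc1` gives 4.1%. All three sit near the bottom of the scale; the steps are a number 3.2 percentage points higher from compound 1 to compound 3 (within the scatter) and a number 1.9 percentage points higher from compound 2 to compound 3 (within the scatter), so compound 3 is not separated from either.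

Compound 4 `Oc1ccc(-c2cc(-c3ccncc3)nc(-c3ccccc3Cl)c2)cc1` differs from compound 3 by pyridin-4-yl in place of thiophen-3-yl on an aromatic carbon. Going by the values given here, the step that bears on this is the reverse of the one from compound 1 to compound 3, where a six-membered ring with one nitrogen gave way to thiophen-3-yl: a number 3.2 percentage points higher from compound 1 to compound 3 (within the scatter), within the scatter. In this assay no step beyond the scatter is therefore expected. Compound 4 is expected to give 2%, between 0% and 8%, which means an expected step of a number 2.1 percentage points lower from compound 3 to compound 4 (within the scatter).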

Compound 4, a percentage reported as inhibition, at one concentration (the size of the read-out at that concentration, not a potency): 9.9%
Beside the measured number, compound 4's estimate is 7.9 percentage points below it; measured number above the stated range.
By their numbers in this assay, from the lowest: compounds 1, 2, 3 and 4 (each within the scatter of the next).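

At this position, on an aromatic carbon next to the ring nitrogen, pyridin-4-yl does not separate from any of the three other groups in this assay (the steps are a number 5.8 percentage points higher from compound 3 to compound 4 (within the scatter) and a number 7.7 percentage points higher from compound 2 to compound 4 (within the scatter) and a number 9 percentage points higher from compound 1 to compound 4 (within the scatter)). Even pyridin-4-yl against pyridin-3-yl, the widest of these steps, stays inside the scatter, so the change of ring shows no effect that can be read. Nothing shown offers an explanation for these numbers.

On these data alone, whether an amine, a carboxylic acid or a longer chain in this place would stand apart from these four compounds remains open.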